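Configuration change from compound 2 to compound 3

The source may report more compounds than this note shows. Statements on the series, on what has been measured and on what is new or still open speak of the compounds shown alone.

In an ADME assay on cells (Hepatocyte, Rattus norvegicus, strain Wistar) for pharmacokinetics, read by LC-MS, with a stated time of 90 min, tested at 1 uM (a higher number here means faster removal of the compound, a lower number slower removal), compound 1 (`COc1cc(C(=O)N2CC(C)(CCO)OC[C@H]2C)cc2nc(N[C@H](C)c3cccc(Cl)c3)oc12`) gives 58.3 mL/min/kg and compound 2 (`COc1cc(C(=O)N2C[C@H](C)OC[C@@H]2CCO)cc2nc(N[C@H](C)c3cccc(Cl)c3)oc12`) gives 45 mL/min/kg as its clearance. These two numbers lie within the scatter of each other, so neither compound can be placed ahead of the other. Compound 3 (`COc1cc(C(=O)N2C[C@@H](C)OC[C@H]2CCO)cc2nc(N[C@H](C)c3cccc(Cl)c3)oc12`) differs from compound 2 in configuration only (the two compounds have the same atoms and bonds and differ only in configuration as drawn: 2 of 3 stereo elements differ; a stereocentre at a saturated ring carbon is drawn S in compound 2 and R in compound 3; a stereocentre at a saturated ring carbon is drawn S in compound 2 and R in compound 3). Within the data shown here, the one measured step of a 1.3-fold lower number from compound 1 to compound 2 (0.11 log units; within the scatter) is a change of substitution, not of configuration alone, and it lies within the scatter. It bears on the new pair only indirectly. Among the measured compounds shown here, no measured pair isolates a change of configuration, so no direction can be assigned in this assay and the expectation stays close to compound 2, with nothing expected beyond the scatter. The estimated step is small (no change at the digits printed from compound 2 to compound 3 (within the scatter)) and carries no firm direction. For compound 3 the expected clearance is 45 mL/min/kg (estimated range 25 mL/min/kg to 70 mL/min/kg).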

Compound 3, clearance: 38.3 mL/min/kg
Compound 3: middle estimate off by 1.2-fold (0.07 log units), on the high side; measured number inside the range.
By their numbers in this assay, from the lowest: compounds 3, 2 and 1 (each within the scatter of the next).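

In this assay, among these compounds, the step from drawn S to drawn R at both saturated ring carbons gives a 1.2-fold lower number from compound 2 to compound 3 (0.07 log units; within the scatter), the first measured step at this position without any change of substitution. The comparison reads on configuration alone: the fact that compounds 2 and 3 differ only in the configuration as drawn. The step of a 1.5-fold lower number from compound 1 to compound 3 (0.18 log units; within the scatter) also stays within the scatter, so the 5-(2-hydroxyethyl)-2-methylmorpholin-4-yl group of compound 3 and the 2-(2-hydroxyethyl)-2,5-dimethylmorpholin-4-yl group of compound 1 cannot be told apart here.

Among the compounds shown here, the two forms with only one of these ring carbons changed remain open, so the pair does not tell whether the two stereocentres would each matter alone. Also open, going by these compounds, is whether a methoxy group or a carboxylic acid in place of the hydroxyl, or a longer chain, would move clearance beyond the scatter.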